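This account rests on a few compounds, and the source may have more. Where it says the series, first, only, none or still open, it means among the compounds named here.

Working notes on the biphenyl acetic acid set. Three compounds have numbers in a physicochemical assay for solubility, in phosphate buffer, measured as kinetic solubility, with a stated time of 1 h, at pH 7.4; on this read-out lower numbers stand for lower solubility and higher numbers for higher solubility. Compound 1 `O=C(O)Cc1ccc(-c2ccc(CN3CC(=O)N(C4CCCCC4)C3=O)cc2)cc1` gives 186 ug/mL in this assay. Compound 2 `O=C(O)Cc1ccc(-c2ccc(N(C(=O)OCc3ccccc3)C3CCCCC3)cc2)cc1` gives 189 ug/mL in this assay. Compound 3 `O=C(O)Cc1ccc(-c2cccc(NC(=O)OCc3ccccc3)c2)cc1` gives 198 ug/mL in this assay. On these numbers compound 2 stands second highest of the three, but its nearest neighbour, compound 1, and its furthest, compound 3, both sit within the usual scatter of it, so the three compounds cannot be told apart on solubility; none of them is the most or least soluble on this evidence.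

Compound 4 `O=C(O)Cc1ccc(-c2ccc(N(C(=O)OCc3ccccc3)C3CCOCC3)cc2)cc1` has no number yet in this assay. It differs from compound 2 in one place: oxan-4-yl in place of cyclohexyl on an amide-type nitrogen. Among the compounds with values here, no pair of measured compounds differs in a single place, so the measured set gives no direct step to lean on for this change, and the three measured values themselves spread less than the scatter. The expected step is a 1.2-fold higher number from compound 2 to compound 4 (0.07 log units; within the scatter), which is estimated to stay within the scatter, with no clear direction. For compound 4 in this assay the estimate is 220 ug/mL, expected to fall between 120 ug/mL and 400 ug/mL.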

Compound 4, solubility: 212 ug/mL
Estimate against measurement, compound 4: 1.0-fold (0.02 log units) above; low and high end bracket the measured number.
By their numbers in this assay, from the lowest: compounds 1, 2, 3 and 4 (each within the scatter of the next).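

Within the data shown here, this is the first step that can be read at a single place: in this assay, oxan-4-yl in place of cyclohexyl on the amide-type nitrogen gives a 1.1-fold higher number from compound 2 to compound 4 (0.05 log units; within the scatter). The exchange keeps the count of heavy atoms and the six-membered ring, and it swaps one ring carbon for an oxygen, which adds a hydrogen-bond acceptor; at this position, and from this starting compound, that change stays within the scatter and no direction can be assigned to it. No measurement shown here explains the size of this step.

The compounds shown leave open whether a ring carrying an amine, such as piperidin-4-yl, or an open chain ending in a carboxylic acid, would stay within the scatter of compound 2 on the same nitrogen. Among these compounds, they also leave open whether oxan-4-yl in place of cyclohexyl would read the same on another scaffold of the series, since this single pair is the only one that isolates the change, and one pair sets no trend.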